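The compounds below may be only part of what the source reports. "The series", "measured", "known", "first", "only" and "open" are said of these compounds alone.

Measured so far in a functional assay on the whole organism (lung, strain A/J) for inhibition, with Mus musculus as the target, with stated times of 1 h and 18 h, at a dose of 100 umol/kg by the oral route; a higher number here means more inhibition at the dose given (going by the name of the read-out), a lower number less inhibition:
compound 1, `COc1cccc(C(=O)N(C)/N=C/c2ccc(OC)c(OC)c2)c1`, 77%
compound 2, `COc1ccc(/C=N/N(C)C(=O)c2ccc(OC)c(OC)c2)cc1OC`, 50%

Compound 2 stands lowest of the two numbers in this assay; its nearest neighbour is compound 1, and the step of a number 27 percentage points lower from compound 1 to compound 2 (beyond the scatter) is beyond the scatter. That step is the only one measured in the series and it concerns adding a methoxy on the shared core.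

Compound 3, `COc1ccc(C(=O)N(C)/N=C/c2ccc(OC)c(OC)c2)cc1`, is not yet measured. It differs from compound 2 as follows: hydrogen in place of methoxy on an aromatic carbon. The change removes a methoxy that sits ortho to the methoxy which compound 1 lacks, so the measured step from compound 1 to compound 2 bears on it only indirectly: both compound 1 and compound 3 carry a single methoxy on that ring, but at different places. Within the data shown here, no measured pair shows removal of this particular methoxy, so the direction is open.

Compound 3 is therefore expected to give about 55% in this assay, with a range of 30% to 80%. The expected step of a number 5 percentage points higher from compound 2 to compound 3 (within the scatter) is estimated to lie within or only modestly beyond the scatter.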

Compound 3, a percentage reported as inhibition, in the whole organism at one dose (the size of the read-out at that dose, not a potency): 68%
For compound 3 the middle estimate is 13 percentage points below the measured one; the range from low to high includes it.
By their numbers in this assay, from the lowest: compound 2; then compounds 3 and 1 (each within the scatter of the next).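

In this assay, hydrogen in place of the methoxy that sits ortho to a methoxy group gives a number 18 percentage points higher from compound 2 to compound 3 (beyond the scatter), so this position responds to the change, and compound 2, with both methoxy groups on that ring, stands beyond the scatter below each compound with only one. The placement of the single methoxy does not separate the other two: 4-methoxyphenyl in place of 3-methoxyphenyl on the carbonyl carbon gives a number 9 percentage points lower from compound 1 to compound 3 (within the scatter). No measurement available here accounts for either step.

Still open, going by these compounds, is how a ring with hydrogen at both places would compare in this assay, and whether an ethoxy or an amine on the same aromatic carbon would follow methoxy. All of these numbers come from a single dose, so they leave relative potency across the series unsettled.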